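This account rests on a few compounds, and the source may have more. Where it says the series, first, only, none or still open, it means among the compounds named here.

Measured so far in a functional assay on MCF7 cells (Homo sapiens) for inhibition, read by sulforhodamine B assay, with a stated time of 48 h; on this read-out higher numbers stand for weaker inhibition of growth and lower numbers for stronger inhibition of growth
compound 1 `c1ccc(COc2ccc(NC3=NCCO3)cc2)cc1` gives 11100 nM
compound 2 `c1ccc(COc2cccc(NC3=NCCO3)c2)cc1` gives 2600 nM
compound 3 `O=C(CCl)NC(=O)Nc1ccc(C2CCCCC2)cc1` gives 1500 nM

Compound 3 at 1500 nM lies within the usual scatter of compound 2 at 2600 nM and cannot be separated from it. Compound 1 at 11100 nM has a number beyond the scatter from that of compound 3, which means weaker inhibition of growth.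

Compound 4 `O=C(CCl)NC(=O)Nc1ccc(OC2CCCCC2)cc1` keeps the rest of compound 3 but has cyclohexyloxy in place of cyclohexyl on an aromatic carbon. For the measured compounds named here, no two measured compounds differ in only one place, so the data offer no direct guide to this change. With so little to go on, the expectation starts from compound 3 at 1500 nM and assumes no step beyond the scatter in this assay. The expected change is small (a 1.2-fold higher number from compound 3 to compound 4 (0.08 log units; within the scatter)). The estimated value for compound 4 is 1800 nM with an expected range from 700 nM to 4500 nM in this test.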

Compound 4, concentration for 50% growth inhibition: 4700 nM
The estimate for compound 4 lay 2.6-fold (0.42 log units) below the measured number; measured number above the stated range.
By their numbers in this assay, from the lowest: compounds 3, 2 and 4 (each within the scatter of the next, the first and the last beyond it); then compound 1.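

In this assay, for the compounds shown here, compound 3 and compound 4 form the first pair that differs in only one place, giving the first direct reading of a change on this aromatic carbon, para to a group of 8 heavy atoms. Cyclohexyloxy in place of cyclohexyl gives a 3.1-fold higher number from compound 3 to compound 4 (0.50 log units; beyond the scatter), a modest step towards weaker inhibition of growth that still clears the usual scatter, so the added oxygen is not a neutral swap at this position. No measurement at hand says why the number rises.

A single pair cannot show whether a shorter ether such as methoxy, an amine or a plain phenyl ring at this place would follow the same direction. It also leaves open whether the same swap would give a similar step on a different core.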